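A Thiophene Replaces the Styryl Group on the Core

The compounds below may be only part of what the source reports. "The series", "measured", "known", "first", "only" and "open" are said of these compounds alone.

Compound 1 `N#CC1=C(N)N(c2ccc(S(N)(=O)=O)cc2)C2=C(C(=O)CCC2)C1/C=C/c1ccccc1` gives 2% in a functional assay on Ehrlich cells (Mus musculus) for antiproliferative activity, read by trypan blue exclusion, with a stated time of 2 h, tested at 10 ug/mL; on this read-out lower numbers stand for a weaker effect and higher numbers for a stronger effect at the one concentration tested.
Compound 2 `COc1ccc(C2C(C#N)=C(N)N(c3ccc(S(N)(=O)=O)cc3)C3=C2C(=O)CCC3)cc1` gives 30%.
Compound 3 `Cc1ccoc1C1C(C#N)=C(N)N(c2ccc(S(N)(=O)=O)cc2)C2=C1C(=O)CCC2` gives 2%.

Among these three numbers compound 1 stands level with compound 3, the two together the lowest, while compound 2 stands higher: a number 28 percentage points higher from compound 1 to compound 2 (beyond the scatter). Compound 4 `N#CC1=C(N)N(c2ccc(S(N)(=O)=O)cc2)C2=C(C(=O)CCC2)C1c1cccs1` is not yet measured. It differs from compound 1 as follows: thiophen-2-yl in place of 2-phenylethenyl on a saturated ring carbon.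

Among the measured compounds shown here, two measured steps bear on this change. Exchanging the same group for 4-methoxyphenyl gave a number 28 percentage points higher from compound 1 to compound 2 (beyond the scatter), whereas exchanging it for 3-methylfuran-2-yl, another five-membered aromatic ring with one hetero atom, gave no change at the digits printed from compound 1 to compound 3 (within the scatter). The furan step is the nearer guide, so no step beyond the scatter is expected: a number 3 percentage points higher from compound 1 to compound 4 (within the scatter). Compound 4 is therefore estimated at 5%, between 0% and 20%.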

Compound 4, a percentage reported as activity, at one concentration (the size of the read-out at that concentration, not a potency): 70%
Estimate against measurement, compound 4: 65 percentage points below; the measured number lies above the stated range.
By their numbers in this assay, from the lowest: compounds 1 and 3 (each within the scatter of the next); then compound 2; then compound 4.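

In this assay the step of a number 68 percentage points higher from compound 3 to compound 4 (beyond the scatter) shows that a five-membered aromatic ring with one hetero atom does not by itself set the read-out at this saturated ring carbon. Thiophen-2-yl also outdoes both groups that carry a six-membered aromatic ring, with a number 68 percentage points higher from compound 1 to compound 4 (beyond the scatter) and a number 40 percentage points higher from compound 2 to compound 4 (beyond the scatter) at the same position.

No measurement at hand explains these jumps. Compound 3 and compound 4 differ in both the hetero atom and the methyl group, so only a furan-2-yl without the methyl, or a 3-methylthiophen-2-yl, could separate the two.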